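Changing the Aryl Group on an Aromatic Nitrogen

The compounds below may be only part of what the source reports. "The series", "measured", "known", "first", "only" and "open" are said of these compounds alone.

Measured compounds:
compound 1 `CC(C)=CCC/C(C)=C/CC/C(C)=C/CC[C@@H]1[C@@]2(C)CC/C(=N\OCc3cn(-c4cccc(C(F)(F)F)c4)nn3)C(C)(C)[C@@H]2CC[C@@]1(C)O` gives 11800 nM in a functional assay on DU-145 cells (Homo sapiens) for cytotoxicity, read by MTT assay, with a stated time of 48 h; on this read-out lower numbers stand for stronger inhibition and higher numbers for weaker inhibition
compound 2 `COc1cccc(-n2cc(COc3ccc(/C=C4\C[C@]5(C)[C@@H](CC/C=C(\C)CC/C=C(\C)CCC=C(C)C)[C@](C)(O)CC[C@H]5C(C)(C)C4=O)cc3)nn2)c1` gives 14500 nM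
compound 3 `CC(C)=CCC/C(C)=C/CC/C(C)=C/CC[C@@H]1[C@@]2(C)C/C(=C\c3ccc(OCc4cn(-c5ccc(Cl)cc5)nn4)cc3)C(=O)C(C)(C)[C@@H]2CC[C@@]1(C)O` gives 79400 nM

Compound 3 has the highest number of the three, standing beyond the scatter from compound 2 and from compound 1. Compound 4 `CC(C)=CCC/C(C)=C/CC/C(C)=C/CC[C@@H]1[C@@]2(C)C/C(=C\c3ccc(OCc4cn(-c5cccc([N+](=O)[O-])c5)nn4)cc3)C(=O)C(C)(C)[C@@H]2CC[C@@]1(C)O` differs from compound 3 in one place: 3-nitrophenyl in place of 4-chlorophenyl on an aromatic nitrogen. For the measured compounds named here, the only measured step that bears on this change is a 5.5-fold higher number from compound 2 to compound 3 (0.74 log units; beyond the scatter), a change of the same aryl group on the same aromatic nitrogen. Going by the values given here, no step with a 3-nitrophenyl group has been measured. Compound 4 is therefore expected to land near compound 3, with a 2.0-fold lower number from compound 3 to compound 4 (0.30 log units; within the scatter) as a modest move toward a lower number, estimated at 40000 nM with a range from 12000 nM to 120000 nM.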

Compound 4, half-maximal inhibitory concentration: 46400 nM
The estimate for compound 4 lay 1.2-fold (0.06 log units) below the measured number; low and high end bracket the measured number.
By their numbers in this assay, from the lowest: compounds 1 and 2 (each within the scatter of the next); then compounds 4 and 3 (each within the scatter of the next).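

In this assay the swap gives a 1.7-fold lower number from compound 3 to compound 4 (0.23 log units; within the scatter) and so does not separate 3-nitrophenyl from 4-chlorophenyl on this aromatic nitrogen, even though the entering group carries 2 hydrogen-bond acceptors and the leaving group none. Against the 3-methoxyphenyl of compound 2, nitro in place of methoxy on an aromatic carbon gives a 3.2-fold higher number from compound 2 to compound 4 (0.51 log units; beyond the scatter) and thus places compound 4 on the same higher side as compound 3. No measured evidence accounts for these numbers. On these data alone, whether an amine or a carboxylic acid on this aryl ring would lower the number remains open, as does where a plain phenyl would fall.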